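The source may hold more compounds than are shown below. What is called first, only, known or untested is meant among the compounds shown, and "the series" means these compounds.

Measured compounds:
compound 1 `C=CC1=C(C(=O)Nc2cccc(C)c2)C(c2ccc(F)cc2)OC1` — "not active" (no number reported)
compound 2 `C=CC1=C(C(=O)Nc2ccc(C)cc2)C(c2ccc(OC)cc2)OC1` — > 100000 nM

In a functional assay on HeLa cells (Homo sapiens) for cytotoxicity, read by MTT assay, with a stated time of 24 h (a higher number here means a weaker inhibitor, a lower number a stronger inhibitor), compound 1 is reported as "not active" (no number reported), without a number. Compound 2 reaches only a limit of the assay, > 100000 nM, and (the limit of > 100000 nM in this assay, at which 1 of the 2 values shown sits). Compound 3 `C=CC1=C(C(=O)NCC(C)C)C(c2ccc(F)cc2)OC1` differs from compound 1 by isobutyl in place of 3-methylphenyl on an amide-type nitrogen. Among the compounds with values here, no measured pair shows what such a swap does, so in this assay no step beyond the usual scatter is expected in either direction. Compound 3 is therefore estimated at 150000 nM, expected between 50000 nM and 500000 nM.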

Compound 3, half-maximal inhibitory concentration: > 100000 nM
Compound 3: no number, only a limit; the forecaster's own chance of this, stated with the estimate: 80%; the middle value is on the limit's open side.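

Compound 1 has no number and compound 3 only a limit, so no step can be read between compound 1 and compound 3: the limit of > 100000 nM in this assay, at which 2 of the 3 values shown sit. The compounds shown leave open whether any group on the amide-type nitrogen gives a measurable value in this assay.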